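The source may report more compounds than this note shows. Statements on the series, on what has been measured and on what is new or still open speak of the compounds shown alone.

Of the compounds shown here, three from this series have been tested in a functional assay on U-87MG ATCC cells for antiproliferative activity against U-87 MG (Homo sapiens), read by MTT assay, with a stated time of 48 h, tested at 5 uM; a higher number here means a weaker effect of the compound at the concentration tested, a lower number a stronger effect. Compound 1, `COc1ccc(-c2nc(C)c(C(=O)CSc3nc(-c4ccc(OC)c(OC)c4)c(C#N)c(=O)[nH]3)s2)cc1`, gives 81.2%. Compound 2, `COc1ccc(-c2nc(SCC(=O)c3sc(-c4ccc(Cl)cc4)nc3C)[nH]c(=O)c2C#N)cc1OC`, gives 93.4%. Compound 3, `Cc1nc(-c2ccc(Cl)cc2)sc1C(=O)CSc1nc(N)c(C#N)c(-c2ccc(Cl)cc2)n1`, gives 46.1%, the lowest of the three numbers and therefore the strongest effect seen so far at the tested concentration; its distance from compound 1 and from compound 2 lies beyond the scatter in both cases.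

Compound 1 and compound 2 share a core and differ in one place: methoxy in place of chloro on an aromatic carbon. That single change gave a number 12.2 percentage points lower from compound 2 to compound 1 (beyond the scatter), a step beyond the scatter but modest in size. Compound 3 carries a different core, and the difference between the two cores is not broken down here.

Compound 4, `COc1ccc(-c2nc(SCC(=O)c3sc(-c4ccc(Cl)cc4)nc3C)nc(N)c2C#N)cc1`, has not yet been measured. It stands to compound 3 exactly as compound 1 stands to compound 2: methoxy in place of chloro on an aromatic carbon. The place of the change is the same in both pairs, so the same change is being made on a different core. Because the earlier example of this change produced a number 12.2 percentage points lower from compound 2 to compound 1 (beyond the scatter), a step of a similar modest size toward a stronger effect is expected here as well, with the caution that one prior example on another core is a thin basis. In this assay the step from compound 3 to compound 4 is expected to be a number 10.1 percentage points lower from compound 3 to compound 4 (beyond the scatter). Compound 4 is therefore estimated to give 36%, plausibly between 18% and 58%.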

Compound 4, a percentage reported as activity, at one concentration (the size of the read-out at that concentration, not a potency): 69.7%
Estimate against measurement, compound 4: 33.7 percentage points below; the measured number lies above the stated range.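

In this assay, going from 4-chlorophenyl to 4-methoxyphenyl on this core gave a number 23.6 percentage points higher from compound 3 to compound 4 (beyond the scatter), which means a weaker effect at the tested concentration. Set beside the earlier example, the same swap moved the read-out in opposite directions on the two cores: the same change on two cores in this assay, a number 12.2 percentage points lower (beyond the scatter) from compound 2 to compound 1 and a number 23.6 percentage points higher (beyond the scatter) from compound 3 to compound 4, 35.8 percentage points apart, beyond the scatter of two such steps. For the compounds shown here, this shows that, in this series, the direction of the step does not carry from one core to the other, so the outcome on one core is a poor guide to the outcome on the other; with only two pairs at a single concentration, it does not show why the steps part ways, or how the change would behave on any further core.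

The compounds shown leave open which feature of the two cores turns the step around, since no pair here changes only one part of the core while the group on the phenyl ring is held fixed. They also leave open whether other groups at the same place on the phenyl ring, such as fluoro, methyl or a dimethylamino group, would follow the chloro or the methoxy compounds on each core.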